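A few compounds are considered here, and "the series" means these few. Any claim that something is new, unique, unknown or untested is made for them only; others in the source may bear on it.

Compound 1 `c1cc2c(s1)CCOC21CCNCC1` is the starting point of this account. In an ADME assay on microsomes from liver (Homo sapiens) for metabolic stability, read by LC-MS, using NADPH, with a stated time of 30 min, tested at 0.5 uM (on this read-out lower numbers stand for slow clearance and higher numbers for fast clearance), compound 1 stands at "not determined" (no result reported), so no number anchors it. Compound 2 `c1cc2c(s1)CCOC21CCN(Cc2cnc3c(c2)OCCO3)CC1`, a second entry from the same core, likewise shows "not determined" (no result reported) in this assay. Going by the values given here, the only number comes from compound 3 `CC(c1ccc(C(F)(F)F)cc1)N1CCC2(CC1)OCCc1sccc12`, which in this assay gives 4.6 mL/min/g. Compound 4 `Cc1ccc(CN2CCC3(CC2)OCCc2sccc23)[nH]1` differs from compound 1 by a single change: (5-methyl-1H-pyrrol-2-yl)methyl in place of hydrogen on an amine nitrogen in a ring. Since compound 1 has no number in this assay, the size of the step from it cannot be set, and its direction is not known from the data. The expectation for compound 4 rests on compound 3 alone, whose 4.6 mL/min/g shows where another entry with a substituted amine nitrogen in a ring lands. Compound 4 is expected to give about 6 mL/min/g in this assay. For compound 4 the expected range runs from 2 mL/min/g to 18 mL/min/g.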

Compound 4, intrinsic clearance in a liver preparation (reported as CLH), per the amount of preparation that the assay uses: 4.1 mL/min/g
Estimate against measurement, compound 4: 1.5-fold (0.17 log units) above; measured number inside the range.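

Going by these compounds alone, compound 1 gives "not determined" (no result reported) in this assay and so no step to compound 4 can be read. The compounds shown leave open how far the (5-methyl-1H-pyrrol-2-yl)methyl group moves clearance from the core of compound 1. Nothing given here accounts for the value of compound 4.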